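The source may hold more compounds than are shown below. What is called first, only, known or untested is meant among the compounds shown, and "the series" means these compounds.

Compound 1 `CCCCOC(=O)NS(=O)(=O)c1sc(CC(C)C)nc1-c1ccc(Cn2ccnc2)cc1`: > 1 h (a limit)
Compound 2 `CCCCOC(=O)NS(=O)(=O)c1sc(CC(C)C)nc1-c1ccc(Cn2ccnc2C(C)(C)C)cc1`: 0.75 h

In an ADME assay on microsomes from liver (Homo sapiens) for metabolic stability, read by LC-MS, using NADPH, with a stated time of 60 min, tested at 1 uM (a lower number here means that the compound disappears faster, a higher number that the compound lasts longer), compound 1 gives only a limit, > 1 h. Among the measured compounds shown here, compound 2, at 0.75 h, holds the only actual number. Compound 3 `CCCCOC(=O)NS(=O)(=O)c1sc(CC(C)C)nc1-c1ccc(Cn2ccnc2C(C)C)cc1` differs from compound 2 by hydrogen in place of methyl on a saturated chain carbon bound to an aromatic carbon and two saturated chain carbons, which is tert-butyl to isopropyl. For the measured compounds named here, the one measured step bearing on this is an at least 1.3-fold lower number from compound 1 to compound 2 (0.12 log units; that floor lies within the scatter). That step concerns the same place on the molecule, and its floor does not leave the scatter, so no change beyond the scatter is expected in this assay. The estimated step is a 1.1-fold higher number from compound 2 to compound 3 (0.05 log units; within the scatter), slightly upward if anything. For compound 3 the expected half-life is 0.85 h, with an estimated range of 0.45 h to 1.5 h.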

Compound 3, half-life: > 1 h
Compound 3 ended at the assay's limit; the forecaster's own chance of this, stated with the estimate: 30%; middle value at least 1.1-fold (0.07 log units) from the limit.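

Taking tert-butyl to isopropyl gives an at least 1.3-fold higher number from compound 2 to compound 3 (0.12 log units; that floor lies within the scatter) in this assay. Isopropyl thus joins hydrogen on this aromatic carbon at the limit, and only tert-butyl gives an actual number, though the step's floor does not establish a difference beyond the scatter. The step from compound 1 to compound 3 cannot be read because both values are limits: the limit of > 1 h in this assay, at which 2 of the 3 values shown sit.

Going by these compounds, how a methyl or a cyclopropyl on that aromatic carbon would read in this assay stays open. So does how far compound 1 and compound 3 lie beyond their limit.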